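A few compounds are considered here, and "the series" means these few. Any claim that something is new, unique, unknown or untested is made for them only; others in the source may bear on it.

Measured so far:
Compound 1 `CN(CCNCc1cn(-c2ccc(F)cc2)nn1)CCNc1ccnc2cc(Cl)ccc12` gives 34000 nM.
Compound 2 `CN(CCNCc1cn(CCCO)nn1)CCNc1ccnc2cc(Cl)ccc12` gives > 200000 nM, a limit of the assay.
Compound 3 `CN(CCNCc1cn(CCC(=O)Nc2ccccn2)nn1)CCNc1ccnc2cc(Cl)ccc12` gives > 200000 nM, also a limit of the assay.

Among the measured compounds shown here, in a functional assay on NCI-H460 cells (Homo sapiens) for antiproliferative activity, read by sulforhodamine B assay, with a stated time of 72 h (a lower number here means a stronger inhibitor, a higher number a weaker inhibitor), compound 1 holds the only true number; the two other values are limits. Compound 4 `CN(CCNCc1cn(CCCn2nn[nH]c2=O)nn1)CCNc1ccnc2cc(Cl)ccc12` differs from compound 1 by a group of 9 heavy atoms (4 carbon, 4 nitrogen, 1 oxygen; one five-membered aromatic ring with 4 hetero atoms) in place of a group of 7 heavy atoms (6 carbon, 1 fluorine; one six-membered aromatic ring of carbon only), on an aromatic nitrogen. For the measured compounds named here, two measured steps bear on this: an at least 5.8-fold higher number from compound 1 to compound 2 (0.76 log units; beyond the scatter) and an at least 5.8-fold higher number from compound 1 to compound 3 (0.76 log units; beyond the scatter), each exchanging the same 4-fluorophenyl on the aromatic nitrogen for a chain-borne group, and each ending at the limit of > 200000 nM in this assay, at which 2 of the 3 values shown sit. A similar weakening is therefore expected for compound 4, a 5.9-fold higher number from compound 1 to compound 4 (0.77 log units; beyond the scatter). Compound 4 is estimated at 200000 nM, between 60000 nM and 600000 nM.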

Compound 4, half-maximal inhibitory concentration: > 200000 nM
Compound 4: no number, only a limit; the forecaster's own chance of this, stated with the estimate: 70%; the middle value lies on the limit itself.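

In this assay, replacing 4-fluorophenyl on the aromatic nitrogen with a chain ending in a five-membered aromatic ring with 4 hetero atoms gives an at least 5.8-fold higher number from compound 1 to compound 4 (0.76 log units; beyond the scatter). Among the compounds shown here, this is a third chain-borne group to give no measurable value, and its ring differs from the one in compound 3, so compound 1 remains the only compound with a true number. The steps among compounds 2, 3 and 4 cannot be read because all three stop at the same limit: the limit of > 200000 nM in this assay, at which 3 of the 4 values shown sit.

Going by these compounds, whether an unsubstituted phenyl or a benzyl on this nitrogen would keep a measurable value remains open. So does the separate contribution of the fluorine atom in compound 1.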